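Replacing 4-bromophenyl with 2,4-dichlorophenyl on compound 3

The compounds below may be only part of what the source reports. "The series", "measured", "known", "first", "only" and "open" are said of these compounds alone.

Values in a functional assay on SW-620 cells (Homo sapiens); a lower number here means a stronger inhibitor of growth, a higher number a weaker inhibitor of growth:
- Compound 1 `O=S(=O)(/C=C/c1ccccc1)Cc1ccc(Nc2ncnc3ccccc23)cc1`: > 100000 nM (a limit)
- Compound 2 `O=S(=O)(/C=C/c1ccc(Cl)c(Cl)c1)Cc1ccc(Nc2ncnc3ccccc23)cc1`: 41000 nM
- Compound 3 `O=S(=O)(/C=C/c1ccc(Br)cc1)Cc1ccc(Nc2ncnc3ccccc23)cc1`: > 100000 nM (a limit)

Compound 3 gives > 100000 nM, which is a limit and not a number. It therefore stands at the limit of > 100000 nM in this assay, at which 2 of the 3 values shown sit.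

The change to compound 4 `O=S(=O)(/C=C/c1ccc(Cl)cc1Cl)Cc1ccc(Nc2ncnc3ccccc23)cc1` is 2,4-dichlorophenyl in place of 4-bromophenyl on a double-bonded chain carbon bound to a double-bonded chain carbon. In words, 2,4-dichlorophenyl comes in place of 4-bromophenyl on a double-bonded chain carbon bound to a double-bonded chain carbon.

Among the compounds with values here, two measured steps bear on this change: an at least 2.4-fold lower number from compound 1 to compound 2 (0.38 log units; beyond the scatter), and an at least 2.4-fold higher number from compound 2 to compound 3 (0.38 log units; beyond the scatter). Both involve 3,4-dichlorophenyl, and the bromo step that the two limits leave unreadable from compound 1 to compound 3 adds nothing. Within the data shown here, no measurement yet covers 2,4-dichlorophenyl itself, so the effect seen with compound 2 at 41000 nM is carried over only in part.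

A shift toward a lower number is expected, and another limit remains possible. The expected step is an at least 1.8-fold lower number from compound 3 to compound 4 (0.25 log units; that floor lies within the scatter). For compound 4 the estimate is 55000 nM, with an expected range of 22000 nM to 120000 nM.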

Compound 4, concentration for 50% growth inhibition: 14000 nM
Estimate against measurement, compound 4: 3.9-fold (0.59 log units) above, and the stated range ends above it.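

In this assay, the two dichlorophenyl compounds can be compared directly, and the arrangement of the chlorines matters: the change gives a 2.9-fold lower number from compound 2 to compound 4 (0.47 log units; beyond the scatter). On the same double-bonded chain carbon, 2,4-dichlorophenyl also gives an at least 7.1-fold lower number from compound 3 to compound 4 (0.85 log units; beyond the scatter) and an at least 7.1-fold lower number from compound 1 to compound 4 (0.85 log units; beyond the scatter), so it improves on both 4-bromophenyl and phenyl. These two steps are floors and not sizes, since compound 1 and compound 3 each start from a limit: the limit of > 100000 nM in this assay, at which 2 of the 4 values shown sit.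

The compounds shown leave open whether both chlorines are needed, as 2-chlorophenyl and 4-chlorophenyl do not appear among them. They also leave open whether the gain carries over to 2,4-difluorophenyl or 2,4-dimethoxyphenyl at this position.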